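This account rests on a few compounds, and the source may have more. Where it says the series, first, only, none or still open, it means among the compounds named here.

Measured so far in an ADME assay on S9 fraction from liver (Rattus norvegicus) for metabolic stability, read by LC-MS, using NADPH, with a stated time of 30 min; a lower number here means that less of the compound is left, a higher number that more of the compound is left:
Compound 1 `CCCCCCCCc1ccc(OCC(=O)Cn2nnnc2-c2ccccn2)cc1`: < 5% (a limit of the assay)
Compound 2 `CCCCCCCCc1ccc(OCC(=O)Cn2nnnc2Cc2ccccc2)cc1`: 26%

Within the data shown here, compound 2 gives 26%, the only actual number in this short series. Compound 1 returns only a limit, < 5%.

Compound 3 `CCCCCCCCc1ccc(OCC(=O)Cn2nnnc2C(=O)OC)cc1` keeps the rest of compound 2 and carries methoxycarbonyl in place of benzyl on an aromatic carbon. Among the measured compounds shown here, the one measured step bears on this same carbon: benzyl in place of pyridin-2-yl gave a number at least 21 percentage points higher from compound 1 to compound 2 (beyond the scatter). The true size of that step is open, and a single step makes no pattern, but it does show that the read-out in this assay can move with the group held there. For the measured compounds named here, compound 2, at 26%, is the only compound with a measured number. The other group tried, in compound 1, sits at the limit of < 5% in this assay, at which 1 of the 2 values shown sits. A modest fall is therefore expected rather than a rise, and compound 3 may itself return only a limit. The expected change is a number 14 percentage points lower from compound 2 to compound 3 (beyond the scatter). The estimate for compound 3 is 12%, with an expected range from 3% to 32%.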

Compound 3, percent of the compound remaining: 38%
Compound 3: the middle estimate sits 26 percentage points below what was measured; measured number above the stated range.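

In this assay, the aromatic carbon between two ring nitrogen atoms tolerates a group with no ring at all: methoxycarbonyl, with fewer heavy atoms than benzyl and with hydrogen-bond acceptors that benzyl lacks, gave a number 12 percentage points higher from compound 2 to compound 3 (beyond the scatter). Measured against pyridin-2-yl the step is large, a number at least 33 percentage points higher from compound 1 to compound 3 (beyond the scatter), and with every step among these compounds beyond the scatter, compound 3 now has the most compound left of the series, so an aromatic ring on this carbon is not needed for the read-out to rise. Compound 1 is now the only compound that returns a limit of the assay, not a number: the limit of < 5% in this assay, at which 1 of the 3 values shown sits.

Benzyl and methoxycarbonyl differ at once in size, in the ring and in the acceptors, so these compounds cannot say which of these differences goes with the higher number. As far as these compounds go, it also remains open whether a carboxylic acid, a primary amide or an ethyl ester on the same carbon would hold the read-out at the level of compound 3, or whether a plain phenyl would place it nearer to compound 2.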